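A few compounds are considered here, and "the series" means these few. Any claim that something is new, unique, unknown or untested is made for them only; others in the source may bear on it.

Measured so far in a functional assay on B16-F0 cells (Mus musculus) for inhibition, read by CCK-8 assay, with a stated time of 48 h; a higher number here means a weaker inhibitor, a lower number a stronger inhibitor:
- compound 1 `COc1cc(-c2ccnc3cc(-c4ccc(F)cc4)nn23)cc(OC)c1OC` gives 4540 nM
- compound 2 `COc1cc(-c2ccnc3cc(-c4ccc5c(ccn5C)c4)nn23)cc(OC)c1OC` gives 48 nM

Compound 2 holds the lower of the two numbers, though a ranking of two compounds is thin. The next compound to be read is compound 3 `COc1cc(-c2ccnc3cc(-c4cn(C)c5ccccc45)nn23)cc(OC)c1OC`, which keeps the shared core and differs only in how the indole is attached: 1-methyl-1H-indol-3-yl in place of 1-methyl-1H-indol-5-yl on an aromatic carbon. Among the measured compounds shown here, the single measured step that bears on this is a 95-fold lower number from compound 1 to compound 2 (1.98 log units; beyond the scatter), where 1-methyl-1H-indol-5-yl replaced 4-fluorophenyl at the same place. That step was large and beyond the scatter, so the number in this pair depends heavily on the group at this place. It does not speak directly to a change of indole attachment, as no second indole has been measured. A moderate rise in this assay therefore seems the likeliest outcome, with much of the gain over 4-fluorophenyl kept, but the uncertainty is wide. The expected change is a 3.1-fold higher number from compound 2 to compound 3 (0.49 log units; beyond the scatter). Compound 3 is estimated at 150 nM, with an expected range from 25 nM to 1200 nM.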

Compound 3, half-maximal inhibitory concentration: 185 nM
Compound 3: the middle estimate sits 1.2-fold (0.09 log units) below what was measured; the range from low to high includes it.
By their numbers in this assay, from the lowest: compound 2; then compound 3; then compound 1.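

In this assay, the same indole joined through a different ring carbon gives a 3.9-fold higher number from compound 2 to compound 3 (0.59 log units; beyond the scatter), so with identical atoms the number at this place still depends on how the group is attached, not only on which group is present. That attachment effect is modest beside the gain over 4-fluorophenyl, which remains large for the 1-methyl-1H-indol-3-yl group, with a 25-fold lower number from compound 1 to compound 3 (1.39 log units; beyond the scatter), so both indole attachments shown stay clearly ahead of 4-fluorophenyl. No measurement at hand accounts for the difference between the two attachments.

Going by these compounds, it remains open whether the methyl on the indole nitrogen matters, which a 1H-indol-5-yl group carrying hydrogen there would test, and whether the indole ring itself is needed or a quinoline, or a phenyl carrying an amine or methoxy group, would serve as well. On these data alone, all three compounds also share the rest of the core, so it is unknown whether the order of these groups would hold if the trimethoxyphenyl part were changed, for instance by replacing a methoxy with a hydroxyl.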